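Benzyl to cyclohexyl on the terminal amine

The source may report more compounds than this note shows. Statements on the series, on what has been measured and on what is new or still open speak of the compounds shown alone.

Measured compounds:
compound 1, `c1ccc(CN(CCCCN(C[C@H]2Cc3ccccc3CN2)[C@H]2CCCc3cccnc32)Cc2ccccn2)nc1`: 664 nM
compound 2, `c1cncc(CN(CCCCN(C[C@H]2Cc3ccccc3CN2)[C@H]2CCCc3cccnc32)Cc2cccnc2)c1`: 471 nM
compound 3, `c1ccc(CNCCCCN(C[C@H]2Cc3ccccc3CN2)[C@H]2CCCc3cccnc32)cc1`: 20.1 nM

In a functional assay on cells for antagonist activity at C-X-C chemokine receptor type 4 (Homo sapiens), read by fluorescence and calcium flux, with stated times of 25 min and 90 s (on this read-out lower numbers stand for stronger inhibition and higher numbers for weaker inhibition), compound 3 gives the lowest number of the three measured; its distances to compound 2 and to compound 1 both lie beyond the scatter, so among these three compound 3 is the most potent. Compound 4, `c1ccc2c(c1)CN[C@@H](CN(CCCCNC1CCCCC1)[C@H]1CCCc3cccnc31)C2`, keeps the core of compound 3 and differs in one place: cyclohexyl in place of benzyl on an amine nitrogen. Among the compounds with values here, no measured pair shows this change, so its size can only be guessed from the structures. The expected step from compound 3 to compound 4 is a 2.0-fold higher number from compound 3 to compound 4 (0.30 log units; within the scatter), a small loss, at the edge of the scatter. For compound 4 in this assay the estimate is 40 nM, with a range from 12 nM to 130 nM.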

Compound 4, half-maximal inhibitory concentration: 75.2 nM
The estimate for compound 4 lay 1.9-fold (0.27 log units) below the measured number, within the range that was stated.
By their numbers in this assay, from the lowest: compound 3; then compound 4; then compounds 2 and 1 (each within the scatter of the next).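

In this assay the change from benzyl to cyclohexyl on the amine nitrogen carries a modest but real cost (a 3.7-fold higher number from compound 3 to compound 4 (0.57 log units; beyond the scatter)). A non-aromatic carbon ring is therefore tolerated at this position, so the aromatic ring of benzyl is not essential for inhibition, although compound 3 keeps the lower number. Nothing available explains the size of this step.

From the compounds shown here alone, it remains open how an isopropyl or phenethyl group on this nitrogen would compare. Also open, going by these compounds, is whether the same step holds on a longer chain.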